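A few compounds are considered here, and "the series" means these few. Any claim that something is new, unique, unknown or untested is made for them only; others in the source may bear on it.

Compounds measured so far in a physicochemical assay for solubility, read by HPLC, using the shake flask method, measured as kinetic solubility, with a stated time of 2 h, at pH 7.4; on this read-out higher numbers stand for higher solubility and lower numbers for lower solubility:

compound 1 `Cc1cc(NCc2ccccn2)n2ncc(-c3ccc(C#N)cc3)c2n1` — compound 1 gives < 5000 nM, a limit of the assay.
compound 2 `Cc1cc(NCc2ccccn2)n2ncc(-c3cccc(Cl)c3)c2n1` — compound 2 gives < 5000 nM, likewise a limit.
compound 3 `Cc1cc(NCc2ccccn2)n2ncc(-c3ccc(F)c(Cl)c3)c2n1` — compound 3 gives < 5000 nM, again a limit.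

Compound 3 thus stands only at a limit, as do the other two; all three values sit at the limit of < 5000 nM in this assay, at which 3 of the 3 values shown sit. The steps a step that the two limits leave unreadable from compound 1 to compound 2, a step that the two limits leave unreadable from compound 1 to compound 3 and a step that the two limits leave unreadable from compound 2 to compound 3 are therefore of unreadable size, and none of them can be put in order.

Compound 4 `Cc1cc(NCc2ccccn2)n2ncc(-c3ccccc3C)c2n1` is not yet measured. It differs from compound 3 in 2-methylphenyl in place of 3-chloro-4-fluorophenyl on an aromatic carbon. The measured steps give no readable size for any aryl change here, so no direction beyond the scatter is expected for a step that the limit leaves unreadable from compound 3 to compound 4. Compound 4 is estimated at 2500 nM, range 400 nM to 9000 nM, most likely again reported as a limit.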

Compound 4, solubility: < 5000 nM
Compound 4 ended at the assay's limit; the forecaster's own chance of this, stated with the estimate: 75%; the middle value does not contradict the limit.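

No step among compound 1, compound 2, compound 3 and compound 4 can be read, since all four values are the same assay limit: the limit of < 5000 nM in this assay, at which 4 of the 4 values shown sit.

The compounds shown leave open whether solubility differs at all between these aryl groups on the shared core.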